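A few compounds are considered here, and "the series" means these few. Any claim that something is new, unique, unknown or untested is made for them only; others in the source may bear on it.

The measured compounds are:
compound 1, `CC(=O)N1CC2CNCC2C1`, giving 2600 nM;
compound 2, `CCC(=O)N1CC2CNCC2C1`, giving 1300 nM;
compound 3, `O=C(c1ccco1)[C@H]1C[C@@H]2CNC[C@@H](C2)C1`, giving "not determined" (no result reported).

In an assay on SHEP1 cells for agonist activity at Neuronal acetylcholine receptor; alpha4/beta2 (Homo sapiens), read by FLIPR and calcium flux (a lower number here means that less compound is needed, a higher number that more compound is needed for the effect), compound 1 and compound 2 stand at micromolar values, and the step from one to the other, a 2.0-fold lower number from compound 1 to compound 2 (0.30 log units; within the scatter), stays within the scatter. Compound 3 stands nowhere on these numbers: it carries a ketone on a different bicyclic core and has no value of its own, so it cannot be placed against compounds 1 and 2.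

Compound 4, `CC(C)NC(=O)[C@H]1C[C@@H]2CNC[C@@H](C2)C1`, is reached from compound 3 by one change: isopropylamino in place of furan-2-yl on a carbonyl carbon. For the measured compounds named here, the only measured step, the one from compound 1 to compound 2, concerns a methyl on a chain carbon beside a carbonyl in the other core and does not touch a ketone-to-amide exchange, so no measured step bears directly on this change. With compound 3 unmeasured, the expectation for compound 4 can rest only on the micromolar level shown by compound 1 at 2600 nM and compound 2 at 1300 nM in this assay. Compound 4 is therefore expected to give about 2000 nM in this assay, with a range from 400 nM to 10000 nM.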

Compound 4, half-maximal effective concentration: 1900 nM
Estimate against measurement, compound 4: 1.1-fold (0.02 log units) above, within the range that was stated.
By their numbers in this assay, from the lowest: compounds 2, 4 and 1 (each within the scatter of the next).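

In this assay compound 4 gives 1900 nM but compound 3 has no number to set against it, so the exchange of furan-2-yl for isopropylamino on the carbonyl carbon cannot be read as a step. Nothing at hand offers an explanation for this value. The compounds shown leave open how compound 3 and compound 4 compare in this assay.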